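The compounds below may be only part of what the source reports. "The series", "measured", "known", "first", "only" and "open" are said of these compounds alone.

The measured compounds:

compound 1, `Cc1ccc(OCC(=O)NNC(=O)c2cc3ccccc3oc2=O)c(C(=O)c2cccc(Cl)c2)c1`, 68600 nM
compound 2, `Cc1ccc(OCC(=O)NNC(=O)c2cc3ccccc3oc2=O)c(C(=O)c2ccccc2Cl)c1`, 54800 nM

For the measured compounds named here, compound 2 holds the lower of the two numbers in a functional assay on DLA cells (Mus musculus) for cytotoxicity, read by trypan blue exclusion, with a stated time of 48 h (a lower number here means a stronger inhibitor, a higher number a weaker inhibitor), but its only neighbour is compound 1, and the step of a 1.3-fold lower number from compound 1 to compound 2 (0.10 log units; within the scatter) does not separate them. The pair therefore says that exchanging a 3-chlorophenyl for a 2-chlorophenyl on this carbonyl carbon leaves the read-out essentially unchanged.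

Compound 3 `Cc1ccc(OCC(=O)NNC(=O)c2cc3ccccc3oc2=O)c(C(=O)c2cccc(Br)c2)c1` is reached from compound 2 by 3-bromophenyl in place of 2-chlorophenyl on a carbonyl carbon. This change has two parts: the halogen-bearing phenyl returns to the 3-substituted pattern of compound 1, and chlorine becomes bromine. Going by the values given here, only the first part has a measured counterpart, the step of a 1.3-fold lower number from compound 1 to compound 2 (0.10 log units; within the scatter), which was within the scatter; the bromine-for-chlorine exchange has no counterpart among the measured compounds. On that basis the account expects compound 3 to land close to both measured values, with a step of about a 1.1-fold higher number from compound 2 to compound 3 (0.04 log units; within the scatter) and no direction beyond the scatter. The estimate for compound 3 is 60000 nM, with a range from 25000 nM to 145000 nM.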

Compound 3, half-maximal inhibitory concentration: 71900 nM
Estimate against measurement, compound 3: 1.2-fold (0.08 log units) below, and the stated range covers the measured number.
By their numbers in this assay, from the lowest: compounds 2, 1 and 3 (each within the scatter of the next).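

For the compounds shown here, the bromine-for-chlorine exchange had no measured counterpart until now: in this assay the step of a 1.0-fold higher number from compound 1 to compound 3 (0.02 log units; within the scatter) shows that bromo in place of chloro on an aromatic carbon leaves the read-out essentially unchanged. The two-part change from 2-chlorophenyl to 3-bromophenyl on this carbonyl carbon also fails to separate its compounds, with the step of a 1.3-fold higher number from compound 2 to compound 3 (0.12 log units; within the scatter) likewise staying within the scatter. Across these three compounds, therefore, neither the identity of the halogen nor the difference between the 2-chlorophenyl, 3-chlorophenyl and 3-bromophenyl groups produces a difference that this read-out can resolve.

No measurement is available that would account for these closely matched numbers. Going by these compounds, it remains open whether a phenyl carrying a group other than a halogen, such as a methoxy group, an amine or a carboxylic acid, or an unsubstituted phenyl, would move the number beyond the scatter at this carbonyl carbon, and whether a change elsewhere on the shared core would do so.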